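Replacing a hydroxyethylaminomethyl arm with chlorine

The source may hold more compounds than are shown below. What is called first, only, known or untested is meant among the compounds shown, and "the series" means these compounds.

For the measured compounds named here, compound 2 `Cn1nc2c(=O)n(CC3(O)CCN(Cc4ccc(-c5ccco5)cc4Cl)CC3)cnc2c1-c1ccc(CNCCO)cc1` holds the lower of the two numbers measured so far. In an assay on isolated protein for inhibition of ubiquitin carboxyl-terminal hydrolase 7 (Homo sapiens), with stated times of 30 min and 2 h (a lower number here means a stronger inhibitor, a higher number a weaker inhibitor), compound 2 gives 8.2 nM, while compound 1 `Cn1nc2c(=O)n(CC3(O)CCN(Cc4ccc(-c5ccco5)cc4Cl)CC3)cnc2c1-c1ccc(C2(N)CC2)cc1` gives 66.1 nM. Going by the values given here, the one measured step, an 8.1-fold lower number from compound 1 to compound 2 (0.91 log units; beyond the scatter), shows that the group carrying the amine and the hydroxyl sits on the stronger side of that comparison. Compound 3 `Cn1nc2c(=O)n(CC3(O)CCN(Cc4ccc(-c5ccco5)cc4Cl)CC3)cnc2c1-c1ccc(Cl)cc1` differs from compound 2 by chloro in place of ((2-hydroxyethyl)amino)methyl on an aromatic carbon. Among the compounds with values here, no measured step removes this arm entirely, so the direction of the change is uncertain, but since the one step seen, an 8.1-fold lower number from compound 1 to compound 2 (0.91 log units; beyond the scatter), favoured the arm, a weaker result is expected once it is gone. In this assay compound 3 is therefore expected to give about 60 nM, within a range from 15 nM to 250 nM, which would mean an estimated step of a 7.3-fold higher number from compound 2 to compound 3 (0.86 log units; beyond the scatter).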

Compound 3, half-maximal inhibitory concentration: 143 nM
For compound 3 the middle estimate is 2.4-fold (0.38 log units) below the measured one; the range from low to high includes it.
By their numbers in this assay, from the lowest: compound 2; then compound 1; then compound 3.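

This aromatic carbon, para to a large group, is sensitive to what it carries: in this assay the change from the ((2-hydroxyethyl)amino)methyl arm to chloro gives a 17-fold higher number from compound 2 to compound 3 (1.24 log units; beyond the scatter), the largest step seen so far. Chloro also gives a weaker result than 1-aminocyclopropyl, with a 2.2-fold higher number from compound 1 to compound 3 (0.34 log units; beyond the scatter), so both amine-bearing groups beat chloro here, though by clearly different margins. The data give no explanation for this order.

From the compounds shown here alone, it remains open whether the amine or the hydroxyl of the arm accounts for its advantage, a question that a plain aminomethyl group or a 2-hydroxyethoxymethyl chain could help answer. Also open, going by these compounds, is how a carboxylic acid at this carbon, or simply a hydrogen, would compare with chloro.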